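This account rests on a few compounds, and the source may have more. Where it says the series, first, only, none or still open, it means among the compounds named here.

Measured compounds:
Compound 1, `Nc1ccccc1NC(=O)c1ccc(CSC(=S)N2CCCc3ccccc32)cc1`: 87.5%
Compound 2, `CC1CCCCN1C(=S)SCc1ccc(C(=O)Nc2ccccc2N)cc1`: 86.9%

Of the compounds shown here, two have been measured in a functional assay on MGC-803 cells (Homo sapiens) for antiproliferative activity, read by CCK-8 assay, with a stated time of 72 h, tested at 8 uM; on this read-out higher numbers stand for a stronger effect at the one concentration tested and lower numbers for a weaker effect. Compound 1, `Nc1ccccc1NC(=O)c1ccc(CSC(=S)N2CCCc3ccccc32)cc1`, gives 87.5% in this assay, and compound 2, `CC1CCCCN1C(=S)SCc1ccc(C(=O)Nc2ccccc2N)cc1`, gives 86.9%. The two share the same core and differ only in the group on the thiocarbonyl carbon; the step of a number 0.6 percentage points lower from compound 1 to compound 2 (within the scatter) is within the scatter, so compound 2 stands alongside compound 1 with no separation that the measurement can support.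

Compound 3, `CC1CCN(C(=S)SCc2ccc(C(=O)Nc3ccccc3N)cc2)CC1`, has not yet been measured in this assay. It differs from compound 2 in one place: 4-methylpiperidin-1-yl in place of 2-methylpiperidin-1-yl on a thiocarbonyl carbon. Within the data shown here, the only measured step that bears on this change is the one from compound 1 to compound 2, where a different ring was put on the same thiocarbonyl carbon and the read-out moved by a number 0.6 percentage points lower from compound 1 to compound 2 (within the scatter), within the scatter. On that basis the expected step of a number 0.9 percentage points lower from compound 2 to compound 3 (within the scatter) is none beyond the scatter. Compound 3 is therefore estimated to give 86% in this assay, in a range from 76% to 96%.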

Compound 3, a percentage reported as inhibition, at one concentration (the size of the read-out at that concentration, not a potency): 81.9%
Compound 3: the middle estimate sits 4.1 percentage points above what was measured; the range from low to high includes it.
By their numbers in this assay, from the lowest: compounds 3, 2 and 1 (each within the scatter of the next).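

The newest pair has the same atoms joined differently, so it isolates the place of the methyl group on the piperidine ring, which the earlier pair of two different ring groups could not do: in this assay, 4-methylpiperidin-1-yl in place of 2-methylpiperidin-1-yl on a thiocarbonyl carbon gives a number 5 percentage points lower from compound 2 to compound 3 (within the scatter). The same group in place of 1,2,3,4-tetrahydroquinolin-1-yl gives a number 5.6 percentage points lower from compound 1 to compound 3 (within the scatter), so at this one concentration, neither a change in the place of the methyl group nor this change of ring separates the three compounds beyond the usual scatter. Nothing available explains these numbers or links them to any feature of the groups.

The compounds shown leave open whether a group of another kind on the thiocarbonyl carbon, such as morpholin-4-yl, an open-chain diethylamino group or a piperidine ring bearing a carboxylic acid, would give a step beyond the scatter. They also leave open whether these three compounds would separate at lower concentrations, since a reading at one concentration is not a potency.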